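A few compounds are considered here, and "the series" means these few. Any claim that something is new, unique, unknown or untested is made for them only; others in the source may bear on it.

In an ADME assay on HEK-293T cells (Homo sapiens) for cytotoxicity, read by MTT assay, with a stated time of 24 h (on this read-out higher numbers stand for lower toxicity in this test and lower numbers for higher toxicity in this test), compound 1 (`O=S(=O)(c1ccc(C(F)(F)F)cc1)n1c(-c2cn(-c3ccccc3)nc2-c2ccc(F)cc2)nc2ccccc21`) gives 241000 nM and compound 2 (`O=[N+]([O-])c1ccc(S(=O)(=O)n2c(-c3cn(-c4ccccc4)nc3-c3ccc(C(F)(F)F)cc3)nc3ccccc32)cc1`) gives 163000 nM. These two numbers lie within the usual scatter of each other, so compound 2 cannot be told apart from compound 1 in this assay. Compound 3 (`O=S(=O)(c1ccc(C(F)(F)F)cc1)n1c(-c2cn(-c3ccccc3)nc2-c2ccc(C(F)(F)F)cc2)nc2ccccc21`) has not yet been measured. It follows from compound 2 with trifluoromethyl in place of nitro on an aromatic carbon, para to a large group, so that 4-nitrophenyl becomes 4-(trifluoromethyl)phenyl: trifluoromethyl in place of nitro on an aromatic carbon. For the measured compounds named here, the measured compounds differ in more than one place, so the data hold no direct step for this change. No shift beyond the scatter is expected in this assay. This expectation rests only on compound 1 at 241000 nM and compound 2 at 163000 nM, which stand within the scatter of each other. The estimated step of a 1.2-fold higher number from compound 2 to compound 3 (0.09 log units; within the scatter) is therefore expected to stay within the scatter. For compound 3 the expected value is 200000 nM, with an estimated range from 110000 nM to 360000 nM.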

Compound 3, half-maximal cytotoxic concentration: 63200 nM
Compound 3: the middle estimate sits 3.2-fold (0.50 log units) above what was measured; the measured number lies below the stated range.
By their numbers in this assay, from the lowest: compound 3; then compounds 2 and 1 (each within the scatter of the next).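

Earlier, compounds 1 and 2 stood within the scatter of each other and differed in more than one place, which left the effect of each change hidden. In this assay, trifluoromethyl in place of nitro on an aromatic carbon gives a 2.6-fold lower number from compound 2 to compound 3 (0.41 log units; beyond the scatter), so this position does affect the read-out, and the lower number stands for higher toxicity in this test. Trifluoromethyl in place of fluoro, at another place on the shared core, gives a 3.8-fold lower number from compound 1 to compound 3 (0.58 log units; beyond the scatter), so both modest steps end at compound 3, the one compound shown with trifluoromethyl at both places; no measurement here offers an explanation for either step.

The compounds shown leave open whether either step holds on a different background, for instance whether the change from nitro to trifluoromethyl would give a similar step with fluoro kept at the other place. They also leave open what an amine or a carboxylic acid on this aromatic carbon would do in this assay, and whether the number would then move further from that of compound 3, in either direction.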